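From methyl to tert-butyl on a saturated chain

This account rests on a few compounds, and the source may have more. Where it says the series, first, only, none or still open, it means among the compounds named here.

For the measured compounds named here, in a functional assay on K562 cells (Homo sapiens) for antiproliferative activity (on this read-out higher numbers stand for weaker inhibition and lower numbers for stronger inhibition), compound 1 (`CCC(=O)N[C@@H]1[C@H]2OC(C)(C)O[C@H]2O[C@@H]1[C@H](O)CO`) gives 30000000 nM and holds the higher of the two numbers so far, while compound 2 (`CCCCC(=O)N[C@@H]1[C@H]2OC(C)(C)O[C@H]2O[C@@H]1[C@H](O)CO`) gives 5000000 nM on the same read-out. Compound 3 (`CC(C)(C)CC(=O)N[C@@H]1[C@H]2OC(C)(C)O[C@H]2O[C@@H]1[C@H](O)CO`) is still unmeasured and differs from compound 1 by tert-butyl in place of methyl on a saturated chain carbon bound to a carbonyl carbon in one place, with tert-butyl in place of methyl on a saturated chain carbon bound to a carbonyl carbon. Going by the values given here, the only measured step that bears on this is a 6.0-fold lower number from compound 1 to compound 2 (0.78 log units; beyond the scatter) and it also adds saturated carbon to the chain, though no tert-butyl. A step toward a lower number, of about that size or somewhat larger, is therefore expected in this assay for this change. The estimated step is a 10-fold lower number from compound 1 to compound 3 (1.00 log units; beyond the scatter) on this reasoning. For compound 3 the expected value is 3000000 nM with 800000 nM and 12000000 nM as the ends of the estimated range.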

Compound 3, half-maximal inhibitory concentration: 5000000 nM
Beside the measured number, compound 3's estimate is 1.7-fold (0.22 log units) below it; the measured number falls inside the stated range.
By their numbers in this assay, from the lowest: compounds 2 and 3 (each within the scatter of the next); then compound 1.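

Placing tert-butyl in place of methyl on a saturated chain carbon bound to a carbonyl carbon gives a 6.0-fold lower number from compound 1 to compound 3 (0.78 log units; beyond the scatter) in this assay, so a branched group at this position lowers the number as the straight chain of compound 2 does. Going to tert-butyl in place of propyl gives no change at the digits printed from compound 2 to compound 3 (within the scatter), so the branched and straight chains of these two compounds cannot be told apart on this read-out. Nothing available explains this result.

Going by these compounds, it remains open whether a longer chain, such as octyl, would take the number lower than compound 2 and compound 3 do, or whether the two values mark a floor for simple saturated chains. How a phenyl ring, an amine or a carboxylic acid would fare at this position is also unknown.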